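A few compounds are considered here, and "the series" means these few. Any claim that something is new, unique, unknown or untested is made for them only; others in the source may bear on it.

Values so far in a functional assay on A549 cells (Homo sapiens) for cytotoxicity, read by MTT assay, with a stated time of 72 h; on this read-out higher numbers stand for weaker inhibition and lower numbers for stronger inhibition:
- compound 1 `COc1ncc(-c2ccc3nc(NC(=O)NCC(=O)N4CCCCC4)nn3c2)cc1NS(=O)(=O)c1ccc(F)cc1` gives 2060 nM
- compound 2 `COc1ncc(-c2ccc3nc(NC(=O)NCCN4CCCCC4)nn3c2)cc1NS(=O)(=O)c1ccc(F)cc1` gives 610 nM
- compound 3 `CCN(CC)CCNC(=O)Nc1nc2ccc(-c3cnc(OC)c(NS(=O)(=O)c4ccc(F)cc4F)c3)cn2n1` gives 980 nM

On these numbers, compound 2 stands within the scatter of compound 3 and clearly under compound 1, the furthest of the three from it.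

Compound 4 `COc1ncc(-c2ccc3nc(NC(=O)NCCN4CCN(C)CC4)nn3c2)cc1NS(=O)(=O)c1ccc(F)cc1` is not yet measured. It differs from compound 2 in one place: 4-methylpiperazin-1-yl in place of piperidin-1-yl on a saturated chain carbon, two bonds along the chain from an amide-type nitrogen.

Going by the values given here, one measured step touches this chain. The step of a 3.4-fold lower number from compound 1 to compound 2 (0.53 log units; beyond the scatter) comes with (piperidin-1-yl)methyl in place of (piperidin-1-yl)carbonyl, and it is modest. Among the compounds with values here, that step leaves the piperidin-1-yl ring itself unchanged, and no measured pair exchanges that ring. Compound 3 differs from compound 2 in more than one place, so it gives no clean comparison. The data thus hold no direct measure of this exchange, and no step beyond the scatter is expected in this assay here.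

The expected change, a 1.2-fold higher number from compound 2 to compound 4 (0.09 log units; within the scatter), is only a rough estimate. For compound 4 the estimated value is 750 nM, with an expected range from 300 nM to 1900 nM for the measurement.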

Compound 4, half-maximal inhibitory concentration: 1050 nM
The estimate for compound 4 lay 1.4-fold (0.15 log units) below the measured number; the measured number falls inside the stated range.
By their numbers in this assay, from the lowest: compounds 2, 3, 4 and 1 (each within the scatter of the next, the first and the last beyond it).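

In this assay, the exchange of the ring itself at this place, 4-methylpiperazin-1-yl in place of piperidin-1-yl on a saturated chain carbon, gives a 1.7-fold higher number from compound 2 to compound 4 (0.24 log units; within the scatter), so on this read-out the chain end takes the ring with 2 hetero atoms without a step that can be told from the scatter. The comparison with the (piperidin-1-yl)carbonyl side chain now reads a 2.0-fold lower number from compound 1 to compound 4 (0.29 log units; within the scatter) beside the earlier 3.4-fold lower number from compound 1 to compound 2 (0.53 log units; beyond the scatter), so the step from compound 1 clears the scatter only with the piperidin-1-yl ring in place. The series offers no evidence that explains either step.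

Open, from the compounds shown here alone, is whether the 4-methyl group of the new ring contributes anything, which a piperazin-1-yl ring with a free ring amine would test, and whether a morpholin-4-yl ring, with oxygen in place of the second nitrogen, would also stay within the scatter of compound 2. Also open, going by these compounds, is how a longer chain, such as 3-(piperidin-1-yl)propyl, would read at this place.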